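Furan-3-yl to 1-benzofuran-2-yl on the shared core

The source may hold more compounds than are shown below. What is called first, only, known or untested is meant among the compounds shown, and "the series" means these compounds.

Compound 1 `CNc1ncnc2c1c(-c1cc3ccccc3o1)cn2[C@@H]1O[C@H](CO)[C@@H](O)[C@H]1O` gives > 20000 nM as a limit of the assay
Compound 2 `CN(C)c1ncnc2c1c(-c1ccoc1)cn2[C@@H]1O[C@H](CO)[C@@H](O)[C@H]1O` gives 1540 nM

For the measured compounds named here, in a functional assay on K562 cells (Homo sapiens), read by MTT assay, with a stated time of 72 h (on this read-out higher numbers stand for weaker inhibition and lower numbers for stronger inhibition), compound 2 gives 1540 nM and this is the only true number so far. Compound 1 sits at > 20000 nM as a limit of the assay, not a number.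

Compound 3 `CN(C)c1ncnc2c1c(-c1cc3ccccc3o1)cn2[C@@H]1O[C@H](CO)[C@@H](O)[C@H]1O` keeps compound 2 except in one place, where 1-benzofuran-2-yl stands in place of furan-3-yl on an aromatic carbon: 1-benzofuran-2-yl in place of furan-3-yl on an aromatic carbon. Going by the values given here, no measured pair isolates this change. Among the compounds with values here, the one guide is compound 1, which also carries 1-benzofuran-2-yl and reaches only its limit of > 20000 nM in this assay as well.

The expected step in this assay is a 9.7-fold higher number from compound 2 to compound 3 (0.99 log units; beyond the scatter), toward weaker inhibition and beyond the scatter. For compound 3 the estimated value is 15000 nM, with an expected range from 4000 nM to 40000 nM, and the assay may well report only a limit.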

Compound 3, half-maximal inhibitory concentration: > 20000 nM
Compound 3: a limit, no number (the forecaster's own chance of this, stated with the estimate: 55%); middle value at least 1.3-fold (0.12 log units) away from the limit.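

Replacing furan-3-yl with 1-benzofuran-2-yl on this aromatic carbon gives, in this assay, an at least 12-fold higher number from compound 2 to compound 3 (1.11 log units; beyond the scatter), so at this position on the shared core the larger group comes with a loss of inhibition beyond the scatter. Compound 3 gives > 20000 nM, a limit of the assay and not a number, so the printed step is only a minimum. The step between compound 1 and compound 3, methyl in place of hydrogen on a nitrogen, cannot be read, and neither compound gives a number: the limit of > 20000 nM in this assay, at which 2 of the 3 values shown sit.

From the compounds shown here alone, whether a phenyl, a thiophen-3-yl or a short chain such as ethyl on this aromatic carbon would keep the inhibition of compound 2 stays open. Also open, going by these compounds, is what methyl in place of hydrogen on that nitrogen does when furan-3-yl is kept.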